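Urea chain length in the sulfonate series

The source may hold more compounds than are shown below. What is called first, only, known or untested is meant among the compounds shown, and "the series" means these compounds.

Within the data shown here, compound 2 `CCCNC(=O)Nc1ccc(S(=O)(=O)Oc2ccccc2C(C)C)cc1` gives the lowest of the two numbers so far in a functional assay on HT-1080 cells (Homo sapiens) for antiproliferative activity, read by sulforhodamine B assay, with a stated time of 48 h; a lower number here means a stronger inhibitor, a higher number a weaker inhibitor: compound 2 gives 680 nM, while compound 1 `CCC(=O)Nc1ccc(S(=O)(=O)Oc2ccccc2C(C)C)cc1` gives 2100 nM, a step of a 3.1-fold lower number from compound 1 to compound 2 (0.49 log units; beyond the scatter). Compound 3 `CCCCCNC(=O)Nc1ccc(S(=O)(=O)Oc2ccccc2C(C)C)cc1` differs from compound 2 by ethyl in place of hydrogen on a saturated chain carbon, three bonds along the chain from an amide-type nitrogen. Among the measured compounds shown here, no measured step concerns such a chain extension; the only step known, a 3.1-fold lower number from compound 1 to compound 2 (0.49 log units; beyond the scatter), changes the carbonyl substituent and does not bear on it. Compound 3 is therefore expected to give a step of a 1.4-fold lower number from compound 2 to compound 3 (0.13 log units; within the scatter). Compound 3 is estimated at 500 nM, range 200 nM to 1500 nM.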

Compound 3, half-maximal inhibitory concentration: 4700 nM
Compound 3: middle estimate off by 9.4-fold (0.97 log units), on the low side; the measured number lies above the stated range.
By their numbers in this assay, from the lowest: compound 2; then compound 1; then compound 3.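

In this assay the gain on the urea side chain does not continue with length: propyl to pentyl gives a clear reversal (a 6.9-fold higher number from compound 2 to compound 3 (0.84 log units; beyond the scatter)). Pentylamino in place of ethyl on the carbonyl carbon also leaves a higher number (a 2.2-fold higher number from compound 1 to compound 3 (0.35 log units; beyond the scatter)), so among these compounds the number does not move in one direction with chain length. No measured evidence on the cause of this turn is available. Open, on these data alone, is where between propyl and pentyl the turn lies, which a butyl chain on the urea would address, and whether a terminal amine or carboxylic acid on the pentyl chain would change the outcome.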